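Changing the amine nitrogen group of compound 2

A few compounds are considered here, and "the series" means these few. Any claim that something is new, unique, unknown or untested is made for them only; others in the source may bear on it.

Compound 1 `CCOC(=O)C1=C(N/C=N/c2nnc(S(N)(=O)=O)s2)Nc2[nH]nc(C)c2C1c1ccc(N(C)C)cc1`: 34500 nM
Compound 2 `CCOC(=O)C1=C(N/N=C(/C(=O)Br)c2ccc(Br)cc2)Nc2[nH]nc(C)c2C1c1ccc(N(C)C)cc1`: 61300 nM
Compound 3 `CCOC(=O)C1=C(NN=C(C#N)C#N)Nc2[nH]nc(C)c2C1c1ccc(N(C)C)cc1`: 12100 nM

In a functional assay on MCF7 cells (Homo sapiens) for inhibition, read by MTT assay, with a stated time of 48 h (a lower number here means a stronger inhibitor, a higher number a weaker inhibitor), compound 2 gives 61300 nM, a number within the scatter of compound 1 and clearly higher than that of compound 3. Compound 4 `CCOC(=O)C1=C(N/C=N/c2ccc(C)cc2)Nc2[nH]nc(C)c2C1c1ccc(N(C)C)cc1` makes one change to compound 2: a group of 9 heavy atoms (8 carbon, 1 nitrogen; one six-membered aromatic ring of carbon only) in place of a group of 12 heavy atoms (8 carbon, 1 nitrogen, 1 oxygen, 2 bromine; one six-membered aromatic ring of carbon only), on an amine nitrogen. Both groups carry a six-membered aromatic ring of carbon only. The two measured compounds whose groups hold a ring differ by just a 1.8-fold higher number from compound 1 to compound 2 (0.25 log units; within the scatter). The larger step is a 5.1-fold lower number from compound 2 to compound 3 (0.70 log units; beyond the scatter), towards a group with no ring, and compound 4 keeps its ring. No step beyond the scatter is therefore expected in this assay, and the estimated move is a 1.8-fold lower number from compound 2 to compound 4 (0.24 log units; within the scatter). For compound 4 the expected value is 35000 nM, with an estimated range of 15000 nM to 80000 nM.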

Compound 4, half-maximal inhibitory concentration: 50500 nM
Compound 4: middle estimate off by 1.4-fold (0.16 log units), on the low side; the measured number falls inside the stated range.
By their numbers in this assay, from the lowest: compound 3; then compounds 1, 4 and 2 (each within the scatter of the next).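

In this assay, removing both bromine atoms and the oxygen from the group on the amine nitrogen changes little (a 1.2-fold lower number from compound 2 to compound 4 (0.08 log units; within the scatter)). Replacing the ring of compound 1 with the 4-methylphenyl of compound 4 on the double-bonded nitrogen also stays within the scatter (a 1.5-fold higher number from compound 1 to compound 4 (0.17 log units; within the scatter)), so a carbon-only ring and a ring with hetero atoms read alike here. A third ring-bearing group still stands apart from the ringless group of compound 3 (a 4.2-fold higher number from compound 3 to compound 4 (0.62 log units; beyond the scatter)).

No measurement here explains that gap. As far as these compounds go, whether the ring itself matters remains open, and a simple amine or a longer chain at this position could help test it.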